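Replacing the Benzylamine Linker with a Thioether

The source may report more compounds than this note shows. Statements on the series, on what has been measured and on what is new or still open speak of the compounds shown alone.

Within the data shown here, compound 1 `Nc1cc(N)c2nc(-c3ccccc3)c(NCc3ccc(F)cc3)nc2c1` gives 7410 nM in a functional assay on SK-MEL-28 cells (Homo sapiens) for inhibition, read by sulforhodamine B assay, with a stated time of 48 h (a lower number here means that less compound is tolerated, a higher number that more compound is tolerated), the lowest of the two numbers known, and compound 2 `COc1ccc(CNc2nc3cc(N)cc(N)c3nc2-c2ccccc2)cc1` gives 60300 nM. Among the measured compounds shown here, the one measured step, an 8.1-fold higher number from compound 1 to compound 2 (0.91 log units; beyond the scatter), alters only the group at the far end of the benzyl ring. For the measured compounds named here, compound 3 `Nc1cc(N)c2nc(-c3ccccc3)c(Sc3ccc(F)cc3)nc2c1` differs from compound 1 by (4-fluorophenyl)sulfanyl in place of (4-fluorobenzyl)amino on an aromatic carbon, a change at the linker that no measured step touches. With nothing to guide direction, compound 3 is expected to land near compound 1, so the step of a 1.3-fold higher number from compound 1 to compound 3 (0.13 log units; within the scatter) is estimated to stay close to the scatter. The estimate for compound 3 is 10000 nM, spanning 2500 nM to 40000 nM.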

Compound 3, concentration lethal to 50% of the cells: < 100000 nM
Compound 3: only a limit was reported; the forecaster's own chance of this, stated with the estimate: 10%; the middle value does not contradict the limit.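

Among these compounds, for compound 3 the assay gives only a limit, < 100000 nM, not a number, so no step from compound 1 to compound 3 can be read. On these data alone, whether (4-fluorophenyl)sulfanyl in place of (4-fluorobenzyl)amino changes the number at all stays open.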